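Adding a methoxy group to a weaker pair member

The source may report more compounds than this note shows. Statements on the series, on what has been measured and on what is new or still open speak of the compounds shown alone.

Compound 1: `CCn1c(=O)/c(=C2\Sc3ccc(OC)cc3N2C)s/c1=C\c1ccncc1Nc1ccccc1C` — 420 nM
Compound 2: `CCn1c(=O)/c(=C2\Sc3ccccc3N2C)s/c1=C\c1ccncc1Nc1ccccc1Cl` — 750 nM

Of the compounds shown here, two have been measured in a functional assay on MCF7 cells (Homo sapiens) for inhibition; a higher number here means a weaker inhibitor, a lower number a stronger inhibitor. Compound 1 gives 420 nM, and compound 2 gives 750 nM. Compound 2 has the highest of the two numbers, but its nearest neighbour, compound 1, lies within the scatter of it, so the two cannot be ranked. Compound 1 and compound 2 also differ in two places at once, so no single step can be read off between them.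

Compound 3, `CCn1c(=O)/c(=C2\Sc3ccc(OC)cc3N2C)s/c1=C\c1ccncc1Nc1ccccc1Cl`, has not yet been measured. It differs from compound 2 by methoxy in place of hydrogen on an aromatic carbon. Within the data shown here, no measured pair shows this change alone, so its size is unknown. The expectation is a step no larger than the scatter, perhaps a small move toward a lower number, as in a 1.4-fold lower number from compound 2 to compound 3 (0.16 log units; within the scatter). Compound 3 is therefore estimated at 520 nM, within a range of 200 nM to 1400 nM in this assay.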

Compound 3, half-maximal inhibitory concentration: 710 nM
Compound 3: middle estimate off by 1.4-fold (0.14 log units), on the low side, within the range that was stated.
By their numbers in this assay, from the lowest: compounds 1, 3 and 2 (each within the scatter of the next).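

In this assay, methoxy in place of hydrogen on this aromatic carbon can now be read alone, and the step (a 1.1-fold lower number from compound 2 to compound 3 (0.02 log units; within the scatter)) lies within the scatter, so this pair shows no measurable effect of the change. Among these compounds, the same compound also gives a first reading of chloro in place of methyl on an aromatic carbon (a 1.7-fold higher number from compound 1 to compound 3 (0.23 log units; within the scatter)), and that step too lies within the scatter. Nothing measured here offers an explanation for either result.

On these data alone, it remains open whether an amine, a carboxylic acid or a longer chain such as ethoxy on the methoxy-bearing carbon would move the number beyond the scatter. As far as these compounds go, the methoxy step also rests on a single pair carrying chloro, so its size with methyl in place of chloro is unknown.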